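The source may hold more compounds than are shown below. What is called first, only, known or untested is meant among the compounds shown, and "the series" means these compounds.

Measured in a functional assay on HeLa cells (Homo sapiens) for inhibition, read by MTT assay, with a stated time of 48 h; a higher number here means a weaker inhibitor, a lower number a stronger inhibitor:
- compound 1 `COc1ccc(/C=C2\SC(=O)N(CCNC(=O)Nc3c(C)n(C)n(-c4ccccc4)c3=O)C2=O)cc1`: 6180 nM
- compound 2 `COc1ccc(/C=C2\SC(=O)N(CC(=O)Nc3c(C)n(C)n(-c4ccccc4)c3=O)C2=O)cc1`: 64800 nM

Compound 2 holds the higher of the two numbers at 64800 nM, making it the weaker inhibitor of the pair. Compound 1, at 6180 nM, lies lower by more than the usual scatter.

The next compound is compound 3 `Cc1cc(C)c(/C=C2\SC(=O)N(CC(=O)Nc3c(C)n(C)n(-c4ccccc4)c3=O)C2=O)c(C)c1`, which is still unmeasured. It departs from compound 2 by one change: 2,4,6-trimethylphenyl in place of 4-methoxyphenyl on a double-bonded chain carbon bound to a double-bonded ring carbon, with 2,4,6-trimethylphenyl in place of 4-methoxyphenyl on a double-bonded chain carbon bound to a double-bonded ring carbon. For the measured compounds named here, no measured pair isolates this change, so the direction remains open, with only a slight lean towards a lower number.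

The step expected in this assay is a 1.4-fold lower number from compound 2 to compound 3 (0.16 log units; within the scatter), none beyond the scatter. For compound 3 the estimated value is 45000 nM, with an expected range of 15000 nM to 120000 nM.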

Compound 3, half-maximal inhibitory concentration: 60900 nM
For compound 3 the middle estimate is 1.4-fold (0.13 log units) below the measured one, within the range that was stated.
By their numbers in this assay, from the lowest: compound 1; then compounds 3 and 2 (each within the scatter of the next).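

In this assay, 2,4,6-trimethylphenyl in place of 4-methoxyphenyl on a double-bonded chain carbon bound to a double-bonded ring carbon gives a 1.1-fold lower number from compound 2 to compound 3 (0.03 log units; within the scatter). For the compounds shown here, this is the first reading at this position, and it shows that in this pair the exchange leaves the values within the scatter, although the entering group carries no hydrogen-bond acceptor and the leaving group carries one. Nothing at hand explains why the exchange has so little effect on the number.

From the compounds shown here alone, whether the same exchange would behave alike with the different chain of compound 1, which gives 6180 nM, remains open. Going by these compounds, how a carboxylic acid or an amine on the aromatic ring at this position would read in this assay also remains open.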